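The compounds below may be only part of what the source reports. "The series", "measured", "known", "first", "only" and "open" are said of these compounds alone.

Measured so far in a functional assay on A549 cells (Homo sapiens) for antiproliferative activity, read by MTT assay, with a stated time of 72 h; on this read-out higher numbers stand for weaker inhibition and lower numbers for stronger inhibition:
- compound 1 `NC1=NC2(CCSCC2)N(OCCCOc2ccc(Br)cc2)C(N)=N1`: 740 nM
- compound 2 `NC1=NC2(CCSCC2)N(OCCCOc2cccc(Cl)c2Cl)C(N)=N1`: 1 nM
- compound 3 `NC1=NC2(CCOCC2)N(OCCCOc2ccc(Cl)c(Cl)c2)C(N)=N1`: 790 nM

Of these three, compound 2 has the lowest number, at 1 nM, and the other two values lie far above it. Compound 4 `NC1=NC2(CCSCC2)N(OCCCOc2ccc(Cl)cc2)C(N)=N1` has not yet been measured. It differs from compound 2 in one place: 4-chlorophenyl in place of 2,3-dichlorophenyl on an oxygen on a saturated carbon. In words, 4-chlorophenyl stands in place of 2,3-dichlorophenyl on an oxygen on a saturated carbon.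

Among the compounds with values here, one measured step bears directly on this change: a 740-fold lower number from compound 1 to compound 2 (2.87 log units; beyond the scatter). That step is large and beyond the scatter, and it also involves the loss or gain of 2,3-dichlorophenyl at this place. Within the data shown here, compound 3 differs from compound 2 in more than one place, so it gives no clean step. Among the measured compounds shown here, compound 4 carries 4-chlorophenyl where compound 1 carries 4-bromophenyl, but no measurement yet compares these two groups directly. The expectation therefore leans on compound 1 at 740 nM, and a large rise in the number in this assay is expected, well beyond the scatter. The expected change is a 400-fold higher number from compound 2 to compound 4 (2.60 log units; beyond the scatter). Compound 4 is estimated at 400 nM, with an expected range from 50 nM to 1800 nM.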

Compound 4, half-maximal inhibitory concentration: 580 nM
Estimate against measurement, compound 4: 1.5-fold (0.16 log units) below; the range from low to high includes it.
By their numbers in this assay, from the lowest: compound 2; then compounds 4, 1 and 3 (each within the scatter of the next).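

In this assay, the change to 4-chlorophenyl in place of 2,3-dichlorophenyl on an oxygen on a saturated carbon gives a 580-fold higher number from compound 2 to compound 4 (2.76 log units; beyond the scatter), so the large gap to compound 2 is now seen with a second group at this place and not with 4-bromophenyl alone. Chloro in place of bromo on an aromatic carbon gives a 1.3-fold lower number from compound 1 to compound 4 (0.11 log units; within the scatter), which lies within the scatter, so in this assay this halogen exchange does not separate the two compounds, while compound 2, with its 2,3-dichlorophenyl group, stands apart from both. No measurement shown here accounts for the size of the step between 2,3-dichlorophenyl and 4-chlorophenyl.

Compound 3 carries two chlorines as well but differs from compound 2 in more than one place, so it cannot show whether the low number of compound 2 depends on the number of chlorines or on their arrangement on the ring. As far as these compounds go, it also remains open how an unsubstituted phenyl, or a methoxy group or a nitrile on the ring, would read in this assay at this place.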